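Bromine on a Shared Ring in Two Different Cores

A few compounds are considered here, and "the series" means these few. Any claim that something is new, unique, unknown or untested is made for them only; others in the source may bear on it.

The study follows one substitution across two cores that share a fused bicyclic ring. Compound 1 `O=C1N=C(N2N=C(c3ccccc3)CC2c2ccccc2O)S/C1=C1/C(=O)Nc2ccccc21` is the unsubstituted parent of the first core. In a functional assay on cells (Cancer cell lines, Homo sapiens) for cytotoxicity, read by sulforhodamine B assay, with a stated time of 48 h (on this read-out higher numbers stand for weaker inhibition of growth and lower numbers for stronger inhibition of growth), compound 1 gives 2030 nM. Compound 2 `O=C1N=C(N2N=C(c3ccccc3)CC2c2ccccc2O)S/C1=C1/C(=O)Nc2ccc(Br)cc21` differs from it only by bromo in place of hydrogen on an aromatic carbon. In this assay compound 2 gives 240 nM, so that the step is an 8.5-fold lower number from compound 1 to compound 2 (0.93 log units; beyond the scatter).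

Compound 3 `COc1ccc(C2=NN(C3=NC(=O)/C(=C4\C(=O)Nc5ccccc54)S3)C(c3ccc(OC)cc3)C2)cc1` belongs to the second core; how this core differs from the core of compound 1 is not broken down here. In this assay compound 3 gives 88100 nM, the highest of the three values and beyond the scatter from both others. Compound 4 `COc1ccc(C2=NN(C3=NC(=O)/C(=C4\C(=O)Nc5ccc(Br)cc54)S3)C(c3ccc(OC)cc3)C2)cc1` has not yet been measured. It differs from compound 3 by bromo in place of hydrogen on an aromatic carbon, the same change that separates compound 1 from compound 2, at a place described in identical words in both pairs.

Whether the change carries over is the open question. Among the measured compounds shown here, the expectation rests on the one measured instance, an 8.5-fold lower number from compound 1 to compound 2 (0.93 log units; beyond the scatter), together with the weak starting point of compound 3 at 88100 nM. Compound 4 is expected to show a step of a 6.8-fold lower number from compound 3 to compound 4 (0.83 log units; beyond the scatter). For the measured compounds named here, this step is set a little below the earlier one because an 8.5-fold lower number from compound 1 to compound 2 (0.93 log units; beyond the scatter) is the only instance of this change known and the second core is a different one. Compound 4 is therefore estimated to give 13000 nM, with a likely range from 3500 nM to 50000 nM.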

Compound 4, concentration for 50% growth inhibition: 200 nM
For compound 4 the middle estimate is 65-fold (1.81 log units) above the measured one; the whole stated range lies above it.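

In this assay, bromo in place of hydrogen on an aromatic carbon gives a 440-fold lower number from compound 3 to compound 4 (2.64 log units; beyond the scatter), so the number falls on both cores, but the size of the step does not carry over from one core to the other: the same change on two cores in this assay, an 8.5-fold lower number (0.93 log units; beyond the scatter) from compound 1 to compound 2 and a 440-fold lower number (2.64 log units; beyond the scatter) from compound 3 to compound 4, 52-fold (1.72 log units) apart, beyond the scatter of two such steps. The direction of the change therefore held in both pairs, while the step measured on the core of compound 1 gave no reliable measure of the step on the core of compound 3. Among the compounds shown here, these two pairs do not show which structural difference between the cores goes with the larger step, and they cannot establish a rule for any further core, since the change is seen on only two cores and in only this one assay.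

The compounds shown leave open whether another group at this place on the six-membered aromatic ring, such as chloro, fluoro, methyl or an amine, would also lower the number and differ in size between the two cores. They also leave open whether bromo at another carbon of that ring would do the same, and which part of the core governs the size of the step.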